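A few compounds are considered here, and "the series" means these few. Any claim that something is new, unique, unknown or untested is made for them only; others in the source may bear on it.

Measured in an assay on cells for inhibition of Amine oxidase [flavin-containing] B (Homo sapiens), read by fluorescence, with stated times of 30 min and 15 min, tested at 1 uM; a higher number here means more inhibition at the concentration tested (going by the name of the read-out), a lower number less inhibition:
compound 1, `COc1ccc(OCCOc2ccc3[nH]c(=O)n(C(C)C)c3c2)cc1`: 15.5%
compound 2, `CCn1c(=O)[nH]c2ccc(OCCOc3ccc(OC)cc3)cc21`: 13.9%
compound 3, `CCn1c(=O)[nH]c2ccc(OCCCOc3ccccc3)cc21`: 11.3%

Compound 1 has the highest of the three numbers, yet its nearest neighbour is compound 2 at a number 1.6 percentage points lower from compound 1 to compound 2 (within the scatter), a step within the scatter that exchanges hydrogen for methyl on the saturated chain carbon bound to the aromatic nitrogen. Compound 3 lies furthest from compound 1, and that gap is also within the scatter. Nothing among these three is separated beyond the noise of this assay.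

Compound 4, `CC(C)n1c(=O)[nH]c2ccc(OCCOc3ccc(Cl)cc3)cc21`, is not yet measured in this assay. Against compound 1 the difference is chloro in place of methoxy on an aromatic carbon. Within the data shown here, no measured step touches this position: the only step available, from compound 1 to compound 2, concerns the group on the aromatic nitrogen, and compound 3 differs from compound 2 in two places at once, so its value alone says little about the aryl substituent. The expectation for compound 4 is therefore a step from compound 1 of a number 1.5 percentage points lower from compound 1 to compound 4 (within the scatter), none beyond the scatter. Compound 4 is estimated at 14%, range 4% to 26%.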

Compound 4, a percentage reported as inhibition, at one concentration (the size of the read-out at that concentration, not a potency): 18.2%
Beside the measured number, compound 4's estimate is 4.2 percentage points below it, within the range that was stated.
By their numbers in this assay, from the lowest: compounds 3, 2, 1 and 4 (each within the scatter of the next).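

The aryl substituent now has its first direct reading. In this assay, the change from 4-methoxyphenyl to 4-chlorophenyl gives a number 2.7 percentage points higher from compound 1 to compound 4 (within the scatter), so replacing methoxy with chloro on this aromatic carbon leaves the read-out indistinguishable at the concentration tested. This is a single pair on the isopropyl-bearing core of compound 1, and nothing available bears on a reason for the result.

Still open, on these data alone, is whether an amine, a carboxylic acid or a nitrile on the same aromatic carbon would produce a step beyond the scatter. As far as these compounds go, it is also open whether chloro would read the same alongside the ethyl group of compound 2, or with a longer chain between the two oxygens.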